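Boronic acid benzylamides: repositioning within the aryl boronic acid

The compounds below may be only part of what the source reports. "The series", "measured", "known", "first", "only" and "open" are said of these compounds alone.

Within the data shown here, compound 2 `CN(Cc1cccc(B(O)O)c1)c1ncc(C(=O)Nc2ccc(F)cc2)cn1` is one of two compounds so far with a number in a functional assay on RBL cells for antagonist activity at C-X-C chemokine receptor type 1 (Homo sapiens), read by fluorescence and calcium flux, with a stated time of 30 min (a lower number here means a stronger inhibitor, a higher number a weaker inhibitor), where compound 2 gives 2500 nM. That is the higher of the two numbers. Its nearest neighbour is compound 1 `CN(Cc1ccc(B(O)O)cc1)c1ccc(C(=O)Nc2ccc(F)cc2)cn1`, which in this assay gives 1400 nM; the gap between compound 2 and compound 1 lies within the scatter of repeated measurements, so no order between them can be read from these two values. Among the measured compounds shown here, compound 1 and compound 2 differ in more than one place, so no single step between them is defined.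

Compound 3 `CN(Cc1ccc(B(O)O)cc1)c1ncc(C(=O)Nc2ccc(F)cc2)cn1` has not yet been measured in this assay. It differs from compound 2 in one place only: a group of 9 heavy atoms (6 carbon, 1 boron, 2 oxygen; one six-membered aromatic ring of carbon only) in place of a group of 9 heavy atoms (6 carbon, 1 boron, 2 oxygen; one six-membered aromatic ring of carbon only), on a saturated chain carbon bound to a nitrogen on an aromatic ring. The two have the same atoms, joined differently.

For the measured compounds named here, no step between measured compounds is available to set the size of such a change. The expectation for compound 3 is therefore a step of a 1.4-fold lower number from compound 2 to compound 3 (0.14 log units; within the scatter) that stays within the scatter, with no clear direction. Compound 3 is estimated at 1800 nM, with a range from 700 nM to 4500 nM.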

Compound 3, half-maximal inhibitory concentration: 681 nM
Compound 3: the middle estimate sits 2.6-fold (0.42 log units) above what was measured, outside the stated range (below it).
By their numbers in this assay, from the lowest: compound 3; then compounds 1 and 2 (each within the scatter of the next).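

In this assay, among these compounds, the change of how the group is joined gives a 3.7-fold lower number from compound 2 to compound 3 (0.56 log units; beyond the scatter) and is the first single change whose size can be read. What leaves and what enters have the same heavy atoms, the same six-membered aromatic ring of carbon only and the same counts of hydrogen-bond donors and acceptors, so at this place, on a saturated chain carbon bound to a nitrogen on an aromatic ring, the number responds to the joining alone. Compound 1 and compound 2 could not show this, as they differ in more than one place and sit within the scatter of each other, and no measurement at hand bears on why the joining matters.

Open, going by these compounds, is whether the same change repeats on the core of compound 1, and whether a carboxylic acid or a nitrile in place of the boronic acid would respond to the joining in the same way. A single step also sets no rule for a longer chain between the aromatic ring and the nitrogen.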